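The compounds below may be only part of what the source reports. "The series", "measured", "known", "first", "only" and "open" are said of these compounds alone.

Compound 1 `Cc1cccc(Nc2nc(C)c(C(=O)/C=C/c3ccc(Cl)cc3)s2)c1` gives > 25000 nM in a functional assay on Bel-7402 cells (Homo sapiens) for cytotoxicity, read by MTT assay (on this read-out lower numbers stand for stronger inhibition and higher numbers for weaker inhibition), which is a limit of the assay.
Compound 2 `Cc1nc(Nc2ccccc2)sc1C(=O)/C=C/c1ccccc1` gives > 25000 nM, also a limit.
Compound 3 `Cc1nc(Nc2ccccc2)sc1C(=O)/C=C/c1ccccc1Cl` gives > 25000 nM, also a limit.

Compound 3 therefore stands where every measured compound stands: its value is a limit, not a number, and all three values rest at the limit of > 25000 nM in this assay, at which 3 of the 3 values shown sit. Among the measured compounds shown here, the only measured change with both ends known runs a step that the two limits leave unreadable from compound 2 to compound 3, chloro in place of hydrogen on an aromatic carbon, and both of its ends are limits, so its size cannot be read. Compound 4 `Cc1nc(Nc2ccccc2)sc1C(=O)/C=C/c1ccc(Cl)cc1` differs from compound 3 by 4-chlorophenyl in place of 2-chlorophenyl on a double-bonded chain carbon bound to a double-bonded chain carbon, the two having the same atoms joined differently. Compound 1 also carries a 4-chlorophenyl on the double-bonded chain carbon, and its value is a limit as well. For the measured compounds named here, no measured step offers a readable size, so nothing in the numbers supports a move beyond the scatter in either direction. The expected step is a step that the limit leaves unreadable from compound 3 to compound 4. Compound 4 is thus expected to stay at the limit, with an estimated value of 50000 nM and a range from 20000 nM to 150000 nM.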

Compound 4, half-maximal inhibitory concentration: > 25000 nM
Compound 4: no number, only a limit; the forecaster's own chance of this, stated with the estimate: 85%; the middle value is on the limit's open side.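

In this assay compound 4 gives > 25000 nM, a limit and not a number. The steps to compound 4 from compound 1, compound 2 and compound 3 therefore cannot be read, all of their ends being limits: the limit of > 25000 nM in this assay, at which 4 of the 4 values shown sit.

The compounds shown leave open how large any of these changes really is, and which change, if any, would bring a measurable value.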